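Exchanging Sulfur for Oxygen in a Small Compound Series

This account rests on a few compounds, and the source may have more. Where it says the series, first, only, none or still open, it means among the compounds named here.

Measured in a functional assay on RKOp27 cells (Homo sapiens) for cytotoxicity, read by MTT assay, with a stated time of 3 days; a lower number here means a stronger inhibitor, a higher number a weaker inhibitor:
- compound 1 `N#Cc1c(O)nc(SCc2nc3ccccc3[nH]2)nc1-c1ccccc1` gives 6.09 nM
- compound 2 `N#Cc1c(Cl)nc(SCc2nc3ccccc3[nH]2)nc1-c1ccccc1` gives 4.38 nM
- compound 3 `N#Cc1c(NC(N)=S)nc(SCc2nc3ccccc3[nH]2)nc1-c1ccccc1` gives 2.63 nM

Two steps show where compound 3 stands: a 2.3-fold lower number from compound 1 to compound 3 (0.36 log units; beyond the scatter), and a 1.7-fold lower number from compound 2 to compound 3 (0.22 log units; within the scatter). It is thus set apart from compound 1 but not from compound 2.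

The next compound, compound 4 `N#Cc1c(NC(N)=O)nc(SCc2nc3ccccc3[nH]2)nc1-c1ccccc1`, carries a single change: a group of 3 heavy atoms (1 carbon, 1 nitrogen, 1 oxygen; no ring) in place of a group of 3 heavy atoms (1 carbon, 1 nitrogen, 1 sulfur; no ring), on a nitrogen on an aromatic ring. Carbamoyl enters on a nitrogen on an aromatic ring. Among the measured compounds shown here, no measured step makes this exchange, so the evidence is indirect. The nearest guides are the replacements on an aromatic carbon, where a 1.4-fold lower number from compound 1 to compound 2 (0.14 log units; within the scatter) and the two steps above are all small. On that basis, no change beyond the scatter is expected in this assay, and no direction can be favoured with confidence. The expected step is a 1.3-fold higher number from compound 3 to compound 4 (0.12 log units; within the scatter). For compound 4 the estimate is 3.5 nM, with an expected range of 1.5 nM to 8 nM.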

Compound 4, half-maximal inhibitory concentration: 2.5 nM
The estimate for compound 4 lay 1.4-fold (0.15 log units) above the measured number, within the range that was stated.
By their numbers in this assay, from the lowest: compounds 4, 3, 2 and 1 (each within the scatter of the next, the first and the last beyond it).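

In this assay, among the compounds shown here, oxygen in place of sulfur in the group on this nitrogen is the first exchange here made within that group, and it leaves the two compounds indistinguishable (a 1.1-fold lower number from compound 3 to compound 4 (0.02 log units; within the scatter)). Measured against the other replacements on the aromatic carbon, ureido stays within the scatter of chloro (a 1.8-fold lower number from compound 2 to compound 4 (0.24 log units; within the scatter)) but goes beyond it against hydroxy (a 2.4-fold lower number from compound 1 to compound 4 (0.39 log units; beyond the scatter)). Compound 4 therefore stands where compound 3 stands, set apart from compound 1 but not from compound 2, so at this position the sulfur is not needed to hold the number in this assay.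

Nothing available accounts for these numbers or says whether the two compounds differ in any other respect. From the compounds shown here alone, whether a plain amine on this aromatic carbon, or acetyl in place of carbamoyl on the nitrogen, would keep the number remains open.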